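The source may hold more compounds than are shown below. What is called first, only, known or untested is meant among the compounds shown, and "the series" means these compounds.

Working notes on the series. Compound 1 `Cc1cccc(CSc2cc(Cl)c(C)cc2S(=O)(=O)/N=C(\N)n2nccc2-c2ccccc2)c1` and compound 2 `Cc1cccc(CSc2cc(Cl)c(C)cc2S(=O)(=O)/N=C(\N)n2nc(C)cc2-c2ccccc2)c1` share one core; in a functional assay on MCF7 cells (Homo sapiens) for cytotoxicity, read by MTT assay, with a stated time of 72 h (a higher number here means a weaker inhibitor, a lower number a stronger inhibitor), compound 1 gives 47000 nM, while compound 2 gives 105000 nM. For the measured compounds named here, the only step so far, a 2.2-fold higher number from compound 1 to compound 2 (0.35 log units; beyond the scatter), places compound 1 as the lower of the two numbers in this assay. Compound 3 `Cc1cc(S(=O)(=O)/N=C(\N)n2nccc2-c2ccccc2)c(SCc2ccccc2C(F)(F)F)cc1Cl` is not yet measured in this assay; it differs from compound 1 as follows: 2-(trifluoromethyl)phenyl in place of 3-methylphenyl on a saturated chain carbon bound to a sulfur. Going by the values given here, no measured step touches this part of the structure, so the exchange of one substituted benzyl for another on the sulfanyl chain has no precedent, and the one step known, a 2.2-fold higher number from compound 1 to compound 2 (0.35 log units; beyond the scatter), concerns a different position. On these grounds no step beyond the scatter is expected from compound 1 to compound 3 in this assay, that is, an expected 1.1-fold higher number from compound 1 to compound 3 (0.03 log units; within the scatter). Compound 3 is therefore estimated at 50000 nM in this assay, within 20000 nM to 130000 nM.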

Compound 3, half-maximal inhibitory concentration: 21000 nM
Compound 3: middle estimate off by 2.4-fold (0.38 log units), on the high side, and the stated range covers the measured number.
By their numbers in this assay, from the lowest: compound 3; then compound 1; then compound 2.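

For the compounds shown here, the sulfanyl benzyl group is the first place where a change gives a lower number in this assay (the step reads a 2.2-fold lower number from compound 1 to compound 3 (0.35 log units; beyond the scatter)), while the only earlier step, at a different position, went the other way (a 2.2-fold higher number from compound 1 to compound 2 (0.35 log units; beyond the scatter)). The aryl group on a saturated chain carbon bound to a sulfur is therefore not indifferent to this exchange, and 2-(trifluoromethyl)phenyl reads better there than 3-methylphenyl. No data at hand bear on the reason for this step.

The exchange alters the group and its ring placement together, and 2-methylphenyl or 3-(trifluoromethyl)phenyl on the same carbon would separate the two. Also open, going by these compounds, are how an amine or a carboxylic acid on that ring would read, and whether the step carries over to the core of compound 2.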